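Vinyl in place of methyl in compound 1

A few compounds are considered here, and "the series" means these few. Any claim that something is new, unique, unknown or untested is made for them only; others in the source may bear on it.

In a functional assay on MDA-MB-231 cells (Homo sapiens) for cytotoxicity, read by MTT assay, with a stated time of 24 h (a lower number here means a stronger inhibitor, a higher number a weaker inhibitor), compound 1 `CCCCCCCCCC(=O)Nc1nnc(S[C@@H]2O[C@H](CO)[C@H](O)[C@H](O)[C@H]2O)s1` gives 53100 nM. Compound 3 `CCCCCCCC/C=C\CCCCCCCCCCCC(=O)Nc1nnc(S[C@@H]2O[C@H](CO)[C@H](O)[C@H](O)[C@H]2O)s1` gives 70400 nM, within the scatter of compound 1. Compound 2 `CCCCCCCCCCCCCCCCCC(=O)Nc1nnc(S[C@@H]2O[C@H](COC(C)=O)[C@H](OC(C)=O)[C@H](OC(C)=O)[C@H]2OC(C)=O)s1` gives 23600 nM, a lower number than compound 1 and beyond the scatter. Compound 1 therefore sits with compound 3 at the higher end of the three numbers.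

Compound 4 `C=CCCCCCCCCC(=O)Nc1nnc(S[C@@H]2O[C@H](CO)[C@H](O)[C@H](O)[C@H]2O)s1` is the next case: vinyl in place of methyl on a saturated chain carbon, eight bonds along the chain from a carbonyl carbon. In words, vinyl replaces methyl on a saturated chain carbon, eight bonds along the chain from a carbonyl carbon.

Among the compounds with values here, only one measured step involves a change on this chain alone. The step of a 1.3-fold higher number from compound 1 to compound 3 (0.12 log units; within the scatter) places dodec-3-en-1-yl in place of hydrogen on a saturated chain carbon, nine bonds along the chain from a carbonyl carbon. That larger change, which also adds a chain double bond, stayed within the scatter. Compound 2 differs from compound 1 in more than one place, so it isolates no single change. Within the data shown here, the change in compound 4 is smaller than the one in compound 3, so no shift beyond the scatter is expected in either direction. The expected step in this assay is a 1.1-fold higher number from compound 1 to compound 4 (0.02 log units; within the scatter).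

The estimate for compound 4 is 56000 nM, with an expected range of 32000 nM to 98000 nM.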

Compound 4, half-maximal inhibitory concentration: 80600 nM
Estimate against measurement, compound 4: 1.4-fold (0.16 log units) below; measured number inside the range.
By their numbers in this assay, from the lowest: compound 2; then compounds 1, 3 and 4 (each within the scatter of the next).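

In this assay the new result is a 1.5-fold higher number from compound 1 to compound 4 (0.18 log units; within the scatter) and thus adds a second single-place change on this chain whose step stays within the scatter. Within the data shown here, until now the only such step was a 1.3-fold higher number from compound 1 to compound 3 (0.12 log units; within the scatter) and it involved a far larger addition, so it said nothing about a small exchange at this place. The new step shows that vinyl in place of methyl on a saturated chain carbon, eight bonds along the chain from a carbonyl carbon, is also not resolved from compound 1, and nothing measured here offers a reason for either step.

Open is whether any replacement at this place moves the number beyond the scatter, for instance a carboxylic acid, an amine or a hydroxyl in place of methyl, since only hydrocarbon changes are shown on this chain. Also open, on these data alone, is whether the exchange of methyl for vinyl would stay within the scatter on a chain attached to the core of compound 2, which carries acetate groups and gives 23600 nM in this series.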